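Vinyl for isopropyl on the quaternary nitrogen

A few compounds are considered here, and "the series" means these few. Any claim that something is new, unique, unknown or untested is made for them only; others in the source may bear on it.

For the measured compounds named here, compound 3 `CC(C)[N+](C)(C)CCCC(=O)[O-]` is the one member of the series that returns a number in an assay for inhibition of gamma-butyrobetaine dioxygenase (Homo sapiens), read by HPLC, with stated times of 15 min and 30 min; on this read-out higher numbers stand for weaker inhibition and lower numbers for stronger inhibition: compound 3 gives 5700 nM. Compound 1 `CCCC[N+](C)(C)CCCC(=O)[O-]` reaches only the limit of this assay, > 1000000 nM, with no number behind it. Compound 2 `C[N+](C)(CCCC(=O)[O-])C1CCCC1` likewise sits at the limit, > 1000000 nM, and not at a number. Going by the values given here, the one step that can be sized runs an at least 170-fold lower number from compound 1 to compound 3 (2.24 log units; beyond the scatter), and this is bounded below by the limit of > 1000000 nM in this assay, at which 2 of the 3 values shown sit, rather than by a measured value for compound 1.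

Compound 4 `C=C[N+](C)(C)CCCC(=O)[O-]` differs from compound 3 by vinyl in place of isopropyl on an amine nitrogen. Among the compounds with values here, the only measured step on this nitrogen shows that trimming the butyl back to isopropyl moved the series from the limit into the measurable range, and no step compares two groups that both return numbers. The vinyl is the smaller of the two groups here, so a step of moderate size in either direction, most likely within or near the scatter, is expected in this assay. The estimate for compound 4 is 3000 nM, within the range 500 nM to 20000 nM, which corresponds to an expected step of a 1.9-fold lower number from compound 3 to compound 4 (0.28 log units; within the scatter).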

Compound 4, half-maximal inhibitory concentration: 127000 nM
Compound 4: the middle estimate sits 42-fold (1.63 log units) below what was measured; the measured number lies above the stated range.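

This position now has two groups that both return numbers, and they do not sit close together: in this assay, vinyl in place of isopropyl gives a 22-fold higher number from compound 3 to compound 4 (1.35 log units; beyond the scatter), so the exchange on this nitrogen is large even though only a small change in heavy atoms is involved. Heavy-atom count alone does not order the three groups, since isopropyl gives a lower number than both butyl, with more heavy atoms, and vinyl, with fewer; vinyl still keeps a measurable number, with an at least 7.8-fold lower number from compound 1 to compound 4 (0.89 log units; beyond the scatter). That step is a bound and not a measured gap, since compound 1 holds only a limit of the assay: the limit of > 1000000 nM in this assay, at which 2 of the 4 values shown sit.

An ethyl on the same nitrogen would carry the same number of heavy atoms as vinyl without the double bond, and the compounds shown cannot separate the part of the step that goes with the double bond from the part that goes with the lost carbon. A propyl or a cyclopropyl at this place would show how narrowly the lowest number shown is tied to isopropyl.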